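Removing One Fluorine: Two Matched Pairs in a Cell Assay

This account rests on a few compounds, and the source may have more. Where it says the series, first, only, none or still open, it means among the compounds named here.

Compound 1 `Cc1cccc(N2CCN(CCCNc3nc(NCc4ccco4)c4ccccc4n3)CC2)c1C` and compound 2 `Cc1cccc(N2CCN(CCCNc3nc(NCc4ccco4)c4cc(F)ccc4n3)CC2)c1C` were both tested in a functional assay on HT-29 cells (Homo sapiens) for cytotoxicity, read by MTT assay, with a stated time of 2 days, tested at 10 uM; on this read-out lower numbers stand for less inhibition and higher numbers for more inhibition at the one concentration tested (going by the name of the read-out). In that assay compound 1 gives 94%, and compound 2 gives 96.7%. For the measured compounds named here, the single change between them is hydrogen in place of fluoro on an aromatic carbon, and the step is a number 2.7 percentage points lower from compound 2 to compound 1 (within the scatter). Compound 3 `CCN(CC)CCNc1nc(NCc2ccco2)c2cc(F)ccc2n1` differs from compound 2 in more than one place; how the two cores differ is not broken down here. In this assay compound 3 gives 27.5%. Compound 4 `CCN(CC)CCNc1nc(NCc2ccco2)c2ccccc2n1` has not yet been measured; it differs from compound 3 by hydrogen in place of fluoro on an aromatic carbon, the same change as from compound 2 to compound 1. Because that earlier step was a number 2.7 percentage points lower from compound 2 to compound 1 (within the scatter), a similarly small step is expected now, a number 1.5 percentage points lower from compound 3 to compound 4 (within the scatter). Compound 4 is therefore estimated at 26%, with a likely range from 15% to 40%.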

Compound 4, a percentage reported as inhibition, at one concentration (the size of the read-out at that concentration, not a potency): 75.1%
The estimate for compound 4 lay 49.1 percentage points below the measured number; the measured number lies above the stated range.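

In this assay, the step for hydrogen in place of fluoro on this core is a number 47.6 percentage points higher from compound 3 to compound 4 (beyond the scatter). The same change therefore did not carry over from one core to the other, and a step seen on one core gave no reliable guide to the step on the other: the same change on two cores in this assay, a number 2.7 percentage points lower (within the scatter) from compound 2 to compound 1 and a number 47.6 percentage points higher (beyond the scatter) from compound 3 to compound 4, 50.3 percentage points apart, beyond the scatter of two such steps This shows that the effect of removing this fluorine depends on the rest of the molecule, but it does not show which part of the cores is responsible, and two pairs cannot predict the step on any further core.

Still open, as far as these compounds go, is how a chloro or methoxy group on that same aromatic carbon would compare on either core. Also open, from the compounds shown here alone, is whether a third core, such as one carrying a morpholine on its chain, would follow either pair.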